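The source may hold more compounds than are shown below. What is called first, only, known or untested is meant among the compounds shown, and "the series" means these compounds.

Measured so far:
- compound 1, `C[C@@H](NC(=O)Nc1cccc(C(F)(F)F)c1)c1ccccc1`, gives 70% in an ADME assay on the whole organism with Oryza sativa as the target, tested at 10 uM; a higher number here means a weaker effect of the compound at the concentration tested, a lower number a stronger effect
- compound 2, `C[C@@H](NC(=O)Nc1ccccc1F)c1ccccc1`, gives 77% in this assay

Among the compounds with values here, compound 2 and compound 1 are the only two measured compounds, and their two readings in this assay sit within the usual scatter of each other, so the two cannot be told apart on these numbers alone. Compound 2 thus stands on a level shared with compound 1 rather than apart from it.

Compound 3, `C[C@@H](NC(=O)Nc1cc(C(F)(F)F)ccc1F)c1ccccc1`, has not yet been measured in this assay. Compared with compound 2, it carries trifluoromethyl in place of hydrogen on an aromatic carbon. Compound 1 already carries a trifluoromethyl group on its own aromatic ring, and its reading is close to that of compound 2. Within the data shown here, with no measured step joining either of them to compound 3, the expected step from compound 2 to compound 3 in this assay is small, a number 7 percentage points lower from compound 2 to compound 3 (within the scatter), with no clear direction beyond the scatter. Compound 3 is therefore estimated to give about 70%, most likely between 50% and 88%.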

Compound 3, a percentage reported as activity, at one concentration (the size of the read-out at that concentration, not a potency): 60%
Beside the measured number, compound 3's estimate is 10 percentage points above it, within the range that was stated.
By their numbers in this assay, from the lowest: compounds 3, 1 and 2 (each within the scatter of the next, the first and the last beyond it).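

In this assay, within the data shown here, trifluoromethyl in place of hydrogen on the aromatic carbon para to the fluoro group gives a number 17 percentage points lower from compound 2 to compound 3 (beyond the scatter), the first step in this small set that lies clear of the scatter, and it points towards a stronger effect at the concentration tested. The other change, fluoro in place of hydrogen on an aromatic carbon, gives a number 10 percentage points lower from compound 1 to compound 3 (within the scatter), so that step cannot be told apart from repeat-to-repeat variation, and on these numbers the trifluoromethyl change is the only one with a readable effect. Nothing measured here accounts for that shift.

Still open, as far as these compounds go, is how an amine or a carboxylic acid on this same aromatic carbon would read. Also open, from the compounds shown here alone, is whether the trifluoromethyl step would be the same size on a ring without the fluoro group.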